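Swapping fluoro for methyl on compound 2

The source may hold more compounds than are shown below. What is called first, only, known or untested is meant among the compounds shown, and "the series" means these compounds.

Compound 1 `Cc1ccc2nc([C@H](CC3CCN(C(=O)C(C)C)CC3)N3C(=O)CN(c4ccc(Oc5ccc(F)cc5)cc4)C3=O)n(C3CC3)c2c1`: 43%
Compound 2 `COc1ccc(Oc2ccc(N3CC(=O)N([C@@H](CC4CCN(C(=O)C(C)C)CC4)c4nc5ccc(F)cc5n4C)C3=O)cc2)cc1`: 24.1%
Compound 3 `CC(C)C(=O)N1CCC(C[C@@H](c2nc3ccc(F)cc3n2C)N2C(=O)CN(c3ccc(Oc4ccc(F)cc4)cc3)C2=O)CC1`: 26.4%

In an ADME assay on microsomes from liver (Mus musculus) for metabolic stability, read by LC-MS, with a stated time of 30 min, tested at 1 ug/mL (a higher number here means that more of the compound is left, a lower number that less of the compound is left), compound 2 gives 24.1%. This is level with compound 3 within the scatter, while compound 1 stands higher by more than the scatter. The next compound, compound 4 `COc1ccc(Oc2ccc(N3CC(=O)N([C@@H](CC4CCN(C(=O)C(C)C)CC4)c4nc5ccc(C)cc5n4C)C3=O)cc2)cc1`, differs from compound 2 in one place: methyl in place of fluoro on an aromatic carbon. In words, it has methyl in place of fluoro on an aromatic carbon.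

Among the compounds with values here, no measured step makes this exact change. Within the data shown here, the only measured single change, a number 2.3 percentage points higher from compound 2 to compound 3 (within the scatter), is fluoro in place of methoxy at a different place in the molecule, so it bears on the question only loosely. Compound 1 carries a methyl too, but it differs from compound 2 in more than one place, so its value cannot be credited to that group. No shift beyond the scatter is therefore expected in this assay. The estimated change is a number 1.1 percentage points lower from compound 2 to compound 4 (within the scatter). Compound 4 is expected at 23%, within an estimated range of 12% to 37%.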

Compound 4, percent of the compound remaining: 2.4%
Estimate against measurement, compound 4: 20.6 percentage points above; the measured number lies below the stated range.
By their numbers in this assay, from the lowest: compound 4; then compounds 2 and 3 (each within the scatter of the next); then compound 1.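

With a single heavy atom exchanged, the move from 6-fluoro-1-methyl-1H-benzimidazol-2-yl to 1,6-dimethyl-1H-benzimidazol-2-yl gives a number 21.7 percentage points lower from compound 2 to compound 4 (beyond the scatter) in this assay. Within the data shown here, this is the first sign in these compounds that the result is sensitive to a single change, since the only earlier one-place step, at the other end of the molecule, was a number 2.3 percentage points higher from compound 2 to compound 3 (within the scatter). It shows that on this aromatic carbon, methyl and fluoro are not interchangeable in this assay, although no measurement shown here accounts for the difference.

The compounds shown leave open whether methyl in place of fluoro at this position would have a similar effect on compound 3, which carries a fluoro in place of the methoxy of compound 2. They also leave open how a chloro or a nitrile on this carbon would compare with the fluoro of compound 2.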